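Inverting one stereocentre of compound 3

A few compounds are considered here, and "the series" means these few. Any claim that something is new, unique, unknown or untested is made for them only; others in the source may bear on it.

Compound 1 `C[C@H](C(=O)NC[C@H](COC(=O)C(C)(C)C)Cc1ccccc1)c1ccc(NS(C)(=O)=O)c(F)c1`: 43 nM
Compound 2 `CC(C(=O)NCC(COC(=O)C(C)(C)C)Cc1ccc(C(C)(C)C)cc1)c1ccc(NS(C)(=O)=O)cc1`: 55 nM
Compound 3 `C[C@@H](C(=O)NC[C@@H](COC(=O)C(C)(C)C)Cc1ccccc1)c1ccc(NS(C)(=O)=O)c(F)c1`: 370 nM

In an assay on CHO cells for displacement of a labelled ligand from transient receptor potential cation channel subfamily V member 1 (Rattus norvegicus) (a lower number here means a stronger inhibitor, a higher number a weaker inhibitor), compound 3 gives 370 nM and stands highest of the three measured numbers; its nearest neighbour is compound 2 with 55 nM, and compound 1 lies furthest away with 43 nM. Among the compounds with values here, the only single-change step among the measured compounds is an 8.6-fold higher number from compound 1 to compound 3 (0.93 log units; beyond the scatter), a modest step that rests on the fact that compounds 1 and 3 differ only in the configuration as drawn and shows that configuration alone moves the number.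

Compound 4 `C[C@H](C(=O)NC[C@@H](COC(=O)C(C)(C)C)Cc1ccccc1)c1ccc(NS(C)(=O)=O)c(F)c1` is reached from compound 3 by the two compounds have the same atoms and bonds and differ only in configuration as drawn: 1 of 2 stereo elements differ; a stereocentre at a saturated chain carbon is drawn R in compound 3 and S in compound 4. Compound 4 therefore shares one stereocentre with compound 1 and the other with compound 3. Since the full inversion gave an 8.6-fold higher number from compound 1 to compound 3 (0.93 log units; beyond the scatter), undoing only one of the two inversions is expected to bring the number part of the way back toward compound 1, so the estimated step is a 4.1-fold lower number from compound 3 to compound 4 (0.61 log units; beyond the scatter), a decrease beyond the scatter. Compound 4 is thus expected to give 90 nM, with a likely range from 30 nM to 300 nM.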

Compound 4, inhibition constant: 16.5 nM
For compound 4 the middle estimate is 5.5-fold (0.74 log units) above the measured one; measured number below the stated range.
By their numbers in this assay, from the lowest: compound 4; then compounds 1 and 2 (each within the scatter of the next); then compound 3.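

The two stereocentres do not carry equal weight: a 22-fold lower number from compound 3 to compound 4 (1.35 log units; beyond the scatter) is a large step, whereas a 2.6-fold lower number from compound 1 to compound 4 (0.42 log units; beyond the scatter) is a modest one, although each inverts a single stereocentre at a saturated chain carbon. Their effects also do not add up, since inverting one centre of compound 1 lowers the number, as compound 4 shows, while inverting both raises it, which places compound 4 outside the span of compounds 1 and 3 rather than part way between them. The large step is a matter of configuration alone: the fact that compounds 3 and 4 differ only in the configuration as drawn

What the mirror image of compound 4 would give remains open, as does which configuration lies behind the value of compound 2, drawn without stereochemistry. Also open, going by these compounds, is whether this order of configurations would hold with an amide or a carboxylic acid in place of the ester.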